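This account rests on a few compounds, and the source may have more. Where it says the series, first, only, none or still open, it means among the compounds named here.

Measured compounds:
- compound 1 `Cc1ccc(-c2cc(N3CCC(CNS(N)(=O)=O)CC3)ncn2)cc1`: 71000 nM
- compound 2 `CCCCc1ccc(-c2cc(N3CCC(CNS(N)(=O)=O)CC3)ncn2)cc1`: 47200 nM
- compound 3 `COC(=O)c1ccc(-c2cc(N3CCC(CNS(N)(=O)=O)CC3)ncn2)cc1`: 14100 nM

In a functional assay on M21 cells (Homo sapiens) for antiproliferative activity, read by sulforhodamine B assay, with a stated time of 48 h (a higher number here means a weaker inhibitor of growth, a lower number a stronger inhibitor of growth), compound 1 gives 71000 nM, the highest of the three numbers. Its nearest neighbour is compound 2, and the step of a 1.5-fold lower number from compound 1 to compound 2 (0.18 log units; within the scatter) is within the scatter. Compound 3 lies furthest away: the step of a 5.0-fold lower number from compound 1 to compound 3 (0.70 log units; beyond the scatter) is modest, and the step of a 3.3-fold lower number from compound 2 to compound 3 (0.52 log units; beyond the scatter) points the same way.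

Compound 4 `NS(=O)(=O)NCC1CCN(c2cc(-c3ccccc3Cl)ncn2)CC1` is not yet measured. It differs from compound 1 in one place: 2-chlorophenyl in place of 4-methylphenyl on an aromatic carbon. Among the measured compounds shown here, none of the measured steps bears directly on this change. For the measured compounds named here, the only change on the phenyl ring that moved the number beyond the scatter, from compound 1 to compound 3, introduced a methoxycarbonyl group; the step from compound 1 to compound 2 changed the chain and stayed within the scatter. Going by the values given here, a chlorine atom, and a different place on the phenyl ring, have no precedent here.

Compound 4 is therefore expected to stay close to compound 1, with no step beyond the scatter in this assay; the expected step is a 1.2-fold lower number from compound 1 to compound 4 (0.07 log units; within the scatter). The estimate for compound 4 in this assay is 60000 nM, with a range from 20000 nM to 160000 nM.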

Compound 4, concentration for 50% growth inhibition: > 100000 nM
Compound 4: only a limit was reported; the forecaster's own chance of this, stated with the estimate: 25%; middle value at least 1.6-fold (0.22 log units) from the limit.
By their numbers in this assay, from the lowest: compound 3; then compounds 2 and 1 (each within the scatter of the next). At a limit, above all of these: compound 4.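

In this assay, compound 4 gives > 100000 nM, which is a limit of the assay and not a number. Replacing 4-methylphenyl with 2-chlorophenyl at this position gives an at least 1.4-fold higher number from compound 1 to compound 4 (0.14 log units; that floor lies within the scatter), so this change, unlike the methoxycarbonyl group of compound 3, brings no lower number, although the floor of the step does not separate compound 4 from compound 1. How far compound 4 really lies from compound 1 cannot be read: the limit of > 100000 nM in this assay, at which 1 of the 4 values shown sits.

The compounds shown leave open whether the result follows from the chlorine atom or from its place on the phenyl ring, a question that 4-chlorophenyl would address. They also leave open whether a carboxylic acid or an amine on the phenyl ring would give a lower number than the methoxycarbonyl group does.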